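A methoxycarbamoyl step from compound 1

The source may report more compounds than this note shows. Statements on the series, on what has been measured and on what is new or still open speak of the compounds shown alone.

compound 1 `CCCCc1nc(Cl)c(CO)n1Cc1ccc(-c2ccccc2-c2[nH]nnc2C(=O)OC)cc1`: 7
compound 2 `CCCCc1nc(Cl)c(COC)n1Cc1ccc(-c2ccccc2C(=O)O)cc1`: 5

In a physicochemical assay (Rattus norvegicus), compound 1 gives 7 and stands highest of the two numbers. Compound 2 gives 5 and lies lower, with the gap beyond the scatter. Compound 3 `CCCCc1nc(Cl)c(CO)n1Cc1ccc(-c2ccccc2C(=O)NOC)cc1` has not yet been measured. It carries methoxycarbamoyl in place of 4-(methoxycarbonyl)-1H-1,2,3-triazol-5-yl on an aromatic carbon. Among the compounds with values here, no measured pair shows this change, so only a moderate upward step in this assay beyond the scatter is expected. Going by these compounds, the estimated change is a number 1.50 log units higher from compound 1 to compound 3 (beyond the scatter) and remains untested. The estimate for compound 3 is 8.5 with an expected range from 7.7 to 9.3 in this assay.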

Compound 3, acid dissociation constant: 10.9
Compound 3: middle estimate off by 2.40 log units, on the low side; the measured number lies above the stated range.
By their numbers in this assay, from the lowest: compound 2; then compound 1; then compound 3.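

Putting methoxycarbamoyl in place of 4-(methoxycarbonyl)-1H-1,2,3-triazol-5-yl, on this aromatic carbon ortho to a large group, gives in this assay a number 3.90 log units higher from compound 1 to compound 3 (beyond the scatter). The read-out at this position therefore responds strongly to the group it carries, and this exchange produces a large step. Nothing on hand explains the size of this step. Which part of the departing group matters remains open, as a single exchange cannot separate its ring from its ester. Where a hydroxycarbamoyl group or a 1H-tetrazol-5-yl ring would fall at this position also remains open.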